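A smaller group on the side chain of compound 1

This account rests on a few compounds, and the source may have more. Where it says the series, first, only, none or still open, it means among the compounds named here.

Of the compounds shown here, two of one series have been measured in an ADME assay on MDCK cells (Canis lupus familiaris) for permeability, read by LC-MS, with a stated time of 90 min, tested at 2 uM; a lower number here means that the compound crosses the layer more slowly, a higher number that the compound crosses the layer faster. Compound 1, with the structure `Cc1cc(C)c(CN2CCc3c(Cl)cc([C@@H](CO)[C@@H]4CCOC4)c(Cl)c3C2=O)c(=O)[nH]1`, gives 3 10^-6 cm/s in this assay. Compound 2, with the structure `COc1cc(C)[nH]c(=O)c1CN1CCc2c(Cl)cc([C@@H](O)C3COC3)c(Cl)c2C1=O`, gives 1.2 10^-6 cm/s in this assay. Of these two numbers, compound 1 stands highest; the gap between compound 1 and compound 2 is beyond the usual scatter of repeated measurements, so compound 1 crosses the cell layer faster than compound 2.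

Compound 3, with the structure `Cc1cc(C)c(CN2CCc3c(Cl)cc([C@H](C)CO)c(Cl)c3C2=O)c(=O)[nH]1`, has not yet been measured in this assay. It differs from compound 1 in one place: methyl in place of oxolan-3-yl on a saturated chain carbon bound to an aromatic carbon and a saturated chain carbon. The rest of the shared core, including both chlorine atoms and the hydroxymethyl group, is kept unchanged.

Within the data shown here, no pair of measured compounds shows this exact change, so the size of the step can only be estimated. A modest upward step is expected, from compound 1 to compound 3 of about a 1.7-fold higher number from compound 1 to compound 3 (0.22 log units; within the scatter) in this assay. Compound 3 is thus estimated to give 5 10^-6 cm/s in this assay, with a likely range from 2.5 10^-6 cm/s to 10 10^-6 cm/s.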

Compound 3, apparent permeability: 12.4 10^-6 cm/s
For compound 3 the middle estimate is 2.5-fold (0.39 log units) below the measured one; the whole stated range lies below it.
By their numbers in this assay, from the lowest: compound 2; then compound 1; then compound 3.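

Among these compounds, putting methyl in place of oxolan-3-yl on a saturated chain carbon bound to an aromatic carbon and a saturated chain carbon gives a 4.1-fold higher number from compound 1 to compound 3 (0.62 log units; beyond the scatter) in this assay, and this is the first measured step that changes only one place. It shows that this position alone can move the number clearly, since both chlorine atoms, the hydroxymethyl group and the rest of the shared core stay the same in the two compounds. Nothing available explains the size of this step, so the numbers record the change without giving its cause.

The step swaps a ring of 5 heavy atoms that holds an oxygen for a single carbon, so it cannot show whether the ring oxygen, the ring itself or the number of atoms accounts for the difference. Cyclopentyl would keep the ring without the oxygen, while ethyl or methoxymethyl would show how the number responds to an open chain longer than methyl, and so would help separate these possibilities.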